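This account rests on a few compounds, and the source may have more. Where it says the series, first, only, none or still open, it means among the compounds named here.

Measured in a physicochemical assay for lipophilicity; on this read-out higher numbers stand for higher lipophilicity and lower numbers for lower lipophilicity:
- compound 1 `CCCOCCNC1=Nc2ccccc2C(C)N1`: 0.1
- compound 2 `CC1NC(NCC2COCCO2)=Nc2ccccc21`: -0.8

Of these two compounds, compound 2 has the lower number, at -0.8. Compound 3 `CCCCNC1=Nc2ccccc2C(C)N1` has propyl in place of 1,4-dioxan-2-yl on a saturated chain carbon bound to an amine nitrogen. Going by the values given here, only one measured step bears on this change: a number 0.90 log units lower from compound 1 to compound 2 (beyond the scatter), which brought in 1,4-dioxan-2-yl at that same place. Removing that group should therefore run the opposite way, although propyl is not propoxymethyl, so the comparison is only approximate. The expected change is upward and modest or somewhat larger: a number 1.20 log units higher from compound 2 to compound 3 (beyond the scatter). Compound 3 is estimated at 0.4, with an expected range of -0.2 to 1.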

Compound 3, distribution coefficient: -0.3
Estimate against measurement, compound 3: 0.70 log units above; the whole stated range lies above it.
By their numbers in this assay, from the lowest: compound 2; then compound 3; then compound 1.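

In this assay there is a number 0.50 log units higher from compound 2 to compound 3 (beyond the scatter) when propyl replaces 1,4-dioxan-2-yl, and a number 0.40 log units lower from compound 1 to compound 3 (beyond the scatter) when ethyl replaces propoxy. The all-carbon chain of compound 3 thus falls between the two oxygen-bearing side chains, so the presence of oxygen in the side chain does not by itself set the direction of the change. Nothing measured here explains this order. Still open, on these data alone, is where a longer carbon chain such as pentyl would fall, and whether a side chain ending in an amine or a carboxylic acid would fall below compound 2.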